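From piperidin-1-yl to 2H-1,2,3-triazol-2-yl: a clearance estimate

The source may hold more compounds than are shown below. What is called first, only, known or untested is meant among the compounds shown, and "the series" means these compounds.

Compound 1 (`NC(=O)c1sc(N2CCCCC2)cc1OCCc1ccccc1`) gives 42 mL.min-1.g-1
Compound 2 (`NC(=O)c1sc(-n2cnc3ccccc32)cc1OCCc1ccccc1`) gives 28 mL.min-1.g-1

In an ADME assay on microsomes from liver (Mus musculus, strain CD-1) for metabolic stability, read by HPLC, using NADPH, with a stated time of 30 min, in the presence of a further agent that is not named here (on this read-out higher numbers stand for fast clearance and lower numbers for slow clearance), compound 1 and compound 2 lie within the usual scatter of each other, so compound 1 cannot be ranked above compound 2. Compound 3 (`NC(=O)c1sc(-n2nccn2)cc1OCCc1ccccc1`), not yet measured, carries 2H-1,2,3-triazol-2-yl in place of piperidin-1-yl on an aromatic carbon. Within the data shown here, no measured pair isolates this change, so the evidence is thin. A modest step towards slower clearance is expected (a 2.3-fold lower number from compound 1 to compound 3 (0.37 log units; beyond the scatter)). The estimated value for compound 3 is 18 mL.min-1.g-1 with an expected range of 7 mL.min-1.g-1 to 40 mL.min-1.g-1 in this assay.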

Compound 3, intrinsic clearance in microsomes: 30 mL.min-1.g-1
Compound 3: middle estimate off by 1.7-fold (0.22 log units), on the low side, within the range that was stated.
By their numbers in this assay, from the lowest: compounds 2, 3 and 1 (each within the scatter of the next).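

In this assay, putting 2H-1,2,3-triazol-2-yl in place of piperidin-1-yl on the aromatic carbon next to the ring sulfur gives a 1.4-fold lower number from compound 1 to compound 3 (0.15 log units; within the scatter). At this position, then, a five-membered aromatic ring and a six-membered non-aromatic ring cannot be told apart on clearance. Nothing available here accounts for this result. On these data alone, it remains open whether a small open-chain group on this carbon, such as dimethylamino or a carboxylic acid, would shift clearance beyond the scatter.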